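The source may report more compounds than this note shows. Statements on the series, on what has been measured and on what is new or still open speak of the compounds shown alone.

Measured compounds:
compound 1, `C=Cc1c(CC)nn(CCCN2CCN(c3ccc(C)cc3)CC2)c(=O)c1N`: 28%
compound 2, `CC(=O)c1cccn1CCCN1CCN(c2ccc(F)cc2)CC1`: 38%
compound 3, `COc1cccc(N2CCN(CCCn3cccc3C(C)=O)CC2)c1`: 52%

In a functional assay on the whole organism (Abdomen, strain Swiss) for inhibition, with Mus musculus as the target, with stated times of 30 min, 10 min and 5 min, at a dose of 40 mg/kg by the oral route (on this read-out higher numbers stand for a stronger effect at the one dose given and lower numbers for a weaker effect), compound 2 stands second highest of the three numbers. Compound 1 lies nearest to it, within the usual scatter, so the two cannot be told apart on this read-out. Among the compounds with values here, the only change that moved the read-out beyond the scatter was a number 14 percentage points higher from compound 2 to compound 3 (beyond the scatter), a modest rise when the aryl group on the amine nitrogen in the ring was exchanged.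

Compound 4, `CC(=O)c1cccn1CCCN1CCN(c2ccc([N+](=O)[O-])cc2)CC1`, differs from compound 2 by nitro in place of fluoro on an aromatic carbon. Within the data shown here, no measured step exchanges fluoro for nitro, so nothing tests this change directly. Among the measured compounds shown here, the one step on that aromatic ring, 3-methoxyphenyl in place of 4-fluorophenyl, was modest, and the present change is a different one. The expectation for compound 4 is therefore a number close to that of compound 2, with no step beyond the scatter, estimated at 40% (between 22% and 58%). This corresponds to an expected step of a number 2 percentage points higher from compound 2 to compound 4 (within the scatter).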

Compound 4, a percentage reported as inhibition, in the whole organism at one dose (the size of the read-out at that dose, not a potency): 0%
Estimate against measurement, compound 4: 40 percentage points above; the whole stated range lies above it.
By their numbers in this assay, from the lowest: compound 4; then compounds 1 and 2 (each within the scatter of the next); then compound 3.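

In this assay, the aromatic carbon para to a large group proves far from indifferent: nitro in place of fluoro gives a number 38 percentage points lower from compound 2 to compound 4 (beyond the scatter). The earlier step on this ring, a number 14 percentage points higher from compound 2 to compound 3 (beyond the scatter), changed both the substituent and where it sits and brought only a modest rise, whereas this exchange leaves the rest of the molecule untouched and removes the effect entirely, with compound 4 at 0%. Nothing measured here accounts for this loss.

On these data alone, it stays open whether the loss belongs to nitro alone or extends to other groups on that carbon, such as a nitrile, an amine or a carboxylic acid. As far as these compounds go, it is also open whether nitro would give the same result on the ring of compound 3, at the place its methoxy group occupies.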